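Extending the dimethylamino chain from compound 2 to compound 3

The source may report more compounds than this note shows. Statements on the series, on what has been measured and on what is new or still open speak of the compounds shown alone.

Measured in a functional assay on cells (Homo sapiens) for antiproliferative activity, read by MTT assay, with a stated time of 48 h; on this read-out higher numbers stand for weaker inhibition and lower numbers for stronger inhibition:
Compound 1 `CN(C)CCn1c(N)c(-c2nc3ccccc3[nH]2)c2nc(C#N)c(C#N)nc21`: 43500 nM
Compound 2 `CN(C)CCn1c(N)c(-c2nc3ccccc3s2)c2nc(C#N)c(C#N)nc21`: > 50000 nM (a limit, not a number)
Compound 3 `CN(C)CCCCn1c(N)c(-c2nc3ccccc3s2)c2nc(C#N)c(C#N)nc21`: not yet measured

Compound 2 stands at the limit of > 50000 nM in this assay, at which 1 of the 2 values shown sits. Compound 3 carries 2-(dimethylamino)ethyl in place of dimethylamino on a saturated chain carbon, two bonds along the chain from an aromatic nitrogen. Among the compounds with values here, the only measured step is an at least 1.1-fold higher number from compound 1 to compound 2 (0.06 log units; that floor lies within the scatter), with 1,3-benzothiazol-2-yl in place of 1H-benzimidazol-2-yl on an aromatic carbon. That step lies elsewhere in the structure and gives no size for a chain change, so no shift beyond the scatter is expected in this assay. The estimated step is an at least 1.2-fold lower number from compound 2 to compound 3 (0.09 log units; that floor lies within the scatter). For compound 3 the expected value is 40000 nM, with an estimated range of 12000 nM to 80000 nM.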

Compound 3, half-maximal inhibitory concentration: 2740 nM
Estimate against measurement, compound 3: 15-fold (1.16 log units) above; measured number outside the range, below it.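

In this assay, the chain on the aromatic nitrogen proves to be a place where the number moves strongly: 2-(dimethylamino)ethyl in place of dimethylamino on a saturated chain carbon gives an at least 18-fold lower number from compound 2 to compound 3 (1.26 log units; beyond the scatter). The earlier step, an at least 1.1-fold higher number from compound 1 to compound 2 (0.06 log units; that floor lies within the scatter), lay elsewhere in the structure and showed nothing about this chain. Compound 2 stands at a limit, so the size of the new step is only a floor: the limit of > 50000 nM in this assay, at which 1 of the 3 values shown sits.

The compounds shown leave open whether 3-(dimethylamino)propyl or a still longer chain would fall on the same course. They also leave open whether a morpholine in place of the dimethylamino would keep the gain.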